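Cyclopropylmethoxy in place of methoxy on a shared core

A few compounds are considered here, and "the series" means these few. Any claim that something is new, unique, unknown or untested is made for them only; others in the source may bear on it.

Measured compounds:
compound 1 `CCCCN(CC)c1nc(C)nc2c1nc(Cl)n2-c1ccc(C(C)C)cc1Br` gives 1.5 nM in an assay on HEK293 cells for binding affinity to corticotropin-releasing factor receptor 1 (Homo sapiens), read by radioligand binding; a higher number here means a weaker inhibitor, a lower number a stronger inhibitor.
compound 2 `CCCCN(CC)c1nc(C)nc2c1nc(OC)n2-c1ccc(C(C)C)cc1Br` gives 1.5 nM in this assay.

Compound 2 stands level with compound 1 at the digits shown, and the step of no change at the digits printed from compound 1 to compound 2 (within the scatter) stays within the scatter. Compound 3 `CCCCN(CC)c1nc(C)nc2c1nc(OCC1CC1)n2-c1ccc(C(C)C)cc1Br` is not yet measured in this assay. It differs from compound 2 by cyclopropyl in place of hydrogen on a saturated chain carbon bound to an oxygen on an aromatic ring, that is, methoxy becoming cyclopropylmethoxy. For the measured compounds named here, the only measured step, no change at the digits printed from compound 1 to compound 2 (within the scatter), concerns the group on the aromatic carbon itself rather than a chain grown from the oxygen, so it bears on this change only loosely. Going by the values given here, with compound 2 at 1.5 nM and no step here beyond the scatter, compound 3 is expected to come out close to compound 2, with the expected step of a 1.3-fold higher number from compound 2 to compound 3 (0.12 log units; within the scatter) small in either direction. The estimate for compound 3 in this assay is 2 nM, between 0.5 nM and 8 nM.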

Compound 3, inhibition constant: 31.1 nM
The estimate for compound 3 lay 16-fold (1.19 log units) below the measured number; the whole stated range lies below it.
By their numbers in this assay, from the lowest: compounds 1 and 2 (each within the scatter of the next); then compound 3.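

In this assay, the place on the shared core that took chloro and methoxy with no visible difference proves sensitive to what is grown from the oxygen: cyclopropyl in place of hydrogen on the saturated chain carbon brings a 21-fold higher number from compound 2 to compound 3 (1.32 log units; beyond the scatter) and so stands well beyond the scatter. Cyclopropylmethoxy in place of chloro brings a 21-fold higher number from compound 1 to compound 3 (1.32 log units; beyond the scatter) and so gives a step of the same size, which means the tolerance seen in the earlier pair does not extend to this larger ether. No supporting evidence is available to explain this drop.

The compounds shown leave open whether the step goes with the cyclopropyl ring itself or with the longer group on the oxygen, a question that an ethoxy or an open butoxy chain would address. Going by these compounds, how an amine would fare at this place also remains open.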